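The compounds below may be only part of what the source reports. "The series", "measured", "known", "first", "only" and "open" are said of these compounds alone.

Measured so far:
- compound 1 `COc1cc(/C=C/C(=O)/C=C/c2cc(OC)c(OC)c(OC)c2)ccc1OCc1cn(CCCCCOc2cc(=O)oc3ccccc23)nn1`: "not active" (no number reported)
- compound 2 `COc1ccccc1/C=C/C(=O)/C=C/c1ccc(OCc2cn(CCCCCOc3cc(=O)oc4ccccc34)nn2)c(OC)c1`: "not active" (no number reported)
- compound 3 `COc1cc(/C=C/C(=O)/C=C/c2cc(OC)c(OC)c(OC)c2)ccc1OCc1cn(CCCOc2cc(=O)oc3ccccc23)nn1`: 12%

All three readings come from a functional assay on PC-3 cells (Homo sapiens) for inhibition, read by sulforhodamine B assay, with a stated time of 48 h, tested at 50 uM; a lower number here means less inhibition of growth, a higher number more inhibition of growth at the concentration tested. Compound 2 stands without a single number there; its entry in this assay is "not active" (no number reported), and compound 1 is the other entry of the same kind. Only compound 3 carries a figure, and in this assay compound 3 gives 12%, a low reading at the concentration tested. Among the measured compounds shown here, no step between two measured compounds that differ in one place is available, so nothing quantifies any structural change yet.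

The step under consideration leads from compound 2 to compound 4 `COc1cc(/C=C/C(=O)/C=C/c2cccs2)ccc1OCc1cn(CCCCCOc2cc(=O)oc3ccccc23)nn1`. The change is thiophen-2-yl in place of 2-methoxyphenyl on a double-bonded chain carbon bound to a double-bonded chain carbon. The rest of the molecule is unchanged.

Without a measured step to lean on, and with compound 2 reported only as not active, the expectation for compound 4 in this assay is a step of no clear direction, and none beyond the scatter. Compound 4 is therefore expected to give about 10%, with a range from 0% to 25%.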

Compound 4, percent growth inhibition at one concentration: "not active" (no number reported)
Compound 4 has no reported number here, so the estimate cannot be set against anything.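

In this assay, among the compounds shown here, compound 2 gives "not active" (no number reported) and compound 4 gives "not active" (no number reported) with no number for either, so no step between them can be read. No measured evidence bears on this result. The compounds shown leave open whether thiophen-2-yl in place of 2-methoxyphenyl alters growth inhibition at all.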